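Chain length and terminal group in a pyrazole binding series

This account rests on a few compounds, and the source may have more. Where it says the series, first, only, none or still open, it means among the compounds named here.

Measured compounds and values:
compound 1 `ClCCCc1cn[nH]c1` 20 nM
compound 2 `ClCCc1cc[nH]n1` 200000 nM
compound 3 `ClCc1cn[nH]c1` 2700 nM

Compound 1 and compound 3 share a core; compound 2 has a different one. In an assay for inhibition of alcohol dehydrogenase (Equus caballus), read by spectrophotometry, in the presence of a further agent that is not named here (on this read-out higher numbers stand for weaker binding and lower numbers for tighter binding), compound 2 gives 200000 nM, the highest number of the three, with compound 3 nearest and compound 1 furthest away. Going by the values given here, the one step between compounds that differ in a single place, a 140-fold higher number from compound 1 to compound 3 (2.13 log units; beyond the scatter), is large and runs toward weaker binding as the chain is shortened, though it sits on the core of compound 1, not on that of compound 2.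

Compound 4 `OCCCc1cc[nH]n1` differs from compound 2 by hydroxymethyl in place of chloro on a saturated chain carbon, two bonds along the chain from an aromatic carbon. The change lengthens the chain by one carbon and exchanges the chlorine for a hydroxyl. Among the compounds with values here, no measured step covers the hydroxyl for chlorine exchange. Only the chain lengthening has a precedent, in the step from compound 1 to compound 3 read in reverse, and on a different core, so the expectation rests on that alone. A move to a lower number is expected for compound 4, but with wide uncertainty: the estimate is 50000 nM, ranging from 5000 nM to 500000 nM, which corresponds to an expected step of a 4.0-fold lower number from compound 2 to compound 4 (0.60 log units; beyond the scatter).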

Compound 4, dissociation constant: 60000 nM
For compound 4 the middle estimate is 1.2-fold (0.08 log units) below the measured one; the measured number falls inside the stated range.
By their numbers in this assay, from the lowest: compound 1; then compound 3; then compound 4; then compound 2.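

In this assay, going by these compounds alone, the only step on the core of compound 2 is a 3.3-fold lower number from compound 2 to compound 4 (0.52 log units; beyond the scatter), which is modest and runs toward tighter binding. It shows that this core, at this place on a saturated chain carbon, two bonds along the chain from an aromatic carbon, accepts hydroxymethyl in place of chloro with a lower number, so a terminal chlorine is not required for binding on this core. The step is much smaller than a 140-fold higher number from compound 1 to compound 3 (2.13 log units; beyond the scatter) on the core of compound 1, although the two are different changes on different cores.

Going by these compounds, whether the added chain carbon or the hydroxyl carries the step stays open, as does how an amine or a carboxylic acid at the chain end would read on either core. Nothing measured here accounts for the size of this step.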